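Cytotoxicity notes on a benzothiazolyl-pyrimidine cyclopentane series

This account rests on a few compounds, and the source may have more. Where it says the series, first, only, none or still open, it means among the compounds named here.

Measured so far:
compound 1 `Nc1nc(Cl)c(-c2nc3ccccc3s2)c(N[C@@H]2C[C@H](CO)[C@@H](O)[C@H]2O)n1`: 14000 nM
compound 2 `CCOCCNc1nc(C)c(-c2nc3ccccc3s2)c(N[C@@H]2C[C@H](CO)[C@@H](O)[C@H]2O)n1`: 18000 nM

In an ADME assay on cells (Homo sapiens) for cytotoxicity, read by polymerase chain reaction, with a stated time of 3 days (a lower number here means that less compound is tolerated, a higher number that more compound is tolerated), compound 2 gives 18000 nM, and compound 1 gives 14000 nM; the two lie within the scatter of each other, so no order between them can be read. Compound 3 `Cc1nc(NCc2ccccn2)nc(N[C@@H]2C[C@H](CO)[C@@H](O)[C@H]2O)c1-c1nc2ccccc2s1` is not yet measured. It differs from compound 2 in one place: pyridin-2-yl in place of ethoxymethyl on a saturated chain carbon bound to a nitrogen on an aromatic ring. Among the measured compounds shown here, no measured pair shows this kind of change, so nothing in the data points to a direction. The step from compound 2 to compound 3 is expected to stay within the scatter, a 1.3-fold lower number from compound 2 to compound 3 (0.11 log units; within the scatter). For compound 3 a value of 14000 nM is estimated, with a range from 5000 nM to 40000 nM.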

Compound 3, half-maximal cytotoxic concentration: 13000 nM
Estimate against measurement, compound 3: 1.1-fold (0.03 log units) above; low and high end bracket the measured number.
By their numbers in this assay, from the lowest: compounds 3, 1 and 2 (each within the scatter of the next).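

Pyridin-2-yl in place of ethoxymethyl on a saturated chain carbon bound to a nitrogen on an aromatic ring comes with a 1.4-fold lower number from compound 2 to compound 3 (0.14 log units; within the scatter) in this assay. This place therefore carries a 2-ethoxyethyl or a (pyridin-2-yl)methyl group with no readable difference in tolerated concentration, and a six-membered aromatic ring enters there without a step beyond the scatter. No supporting data on hand offer an explanation for this result.

As far as these compounds go, whether a carboxylic acid or a primary amine on this chain, or a longer chain, would give a step beyond the scatter stays open.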